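Swapping the ester group on a statin-like core

The compounds below may be only part of what the source reports. "The series", "measured", "known", "first", "only" and "open" are said of these compounds alone.

Measured compounds:
- compound 1 `CC(=O)O[C@H]1C[C@@H](C)C=C2C=C[C@H](C)[C@H](CC[C@@H]3C[C@@H](O)CC(=O)O3)C21`: 269 nM
- compound 2 `CCC(C)(CC)C(=O)O[C@H]1C[C@@H](C)C=C2C=C[C@H](C)[C@H](CC[C@@H]3C[C@@H](O)CC(=O)O3)C21`: 1.4 nM

Both compounds were tested in an assay for inhibition of 3-hydroxy-3-methylglutaryl-coenzyme A reductase (Rattus norvegicus); a lower number here means a stronger inhibitor, a higher number a weaker inhibitor. Compound 1 carries an acetyl ester on the shared core and gives 269 nM. Among the measured compounds shown here, compound 2 carries a much larger branched acyl group in the same place and gives 1.4 nM, the lower of the two numbers; the only measured step that exists, a 190-fold lower number from compound 1 to compound 2 (2.28 log units; beyond the scatter), shows how strongly the size of this acyl group moves the result.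

Compound 3 `C[C@H]1C=C2C=C[C@H](C)[C@H](CC[C@@H]3C[C@@H](O)CC(=O)O3)C2[C@@H](OC(=O)c2ccc(F)cc2)C1` keeps the same core and the same ester oxygen, but the acyl group is changed: 4-fluorophenyl in place of 1-ethyl-1-methylpropyl on a carbonyl carbon. For the measured compounds named here, no measured step covers an aromatic group in this place, so the acetyl-to-branched-alkyl step is the only guide. It shows that the group on this carbonyl matters a great deal; a flat aromatic ring is neither as small as acetyl nor the same as the branched chain. For compound 3 a moderately higher number than compound 2 is therefore expected, a 14-fold higher number from compound 2 to compound 3 (1.15 log units; beyond the scatter), with an estimate of 20 nM and a range from 4 nM to 100 nM.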

Compound 3, half-maximal inhibitory concentration: 37 nM
Beside the measured number, compound 3's estimate is 1.9-fold (0.27 log units) below it, and the stated range covers the measured number.
By their numbers in this assay, from the lowest: compound 2; then compound 3; then compound 1.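

In this assay, the 4-fluorophenyl ester falls between the other two: replacing methyl with this ring gives a 7.3-fold lower number from compound 1 to compound 3 (0.86 log units; beyond the scatter), while replacing 1-ethyl-1-methylpropyl with it gives a 26-fold higher number from compound 2 to compound 3 (1.42 log units; beyond the scatter). A branched alkyl chain is therefore not the only group on this carbonyl carbon that gives a lower number than methyl, though among these three compounds 1-ethyl-1-methylpropyl gives the lowest number. Size, counted as heavy atoms, does not settle the result either: 1-ethyl-1-methylpropyl has 6 and 4-fluorophenyl has 7, yet the numbers lie well apart, and no measurement offered here explains that gap.

On these data alone, what the fluorine itself contributes remains open, and a plain phenyl group or a chlorine in its place on the ring would test that. It is also unclear whether the difference between compound 2 and compound 3 follows from the ring or from the branching, a question that a cyclohexyl group or an unbranched pentyl chain on the same carbonyl carbon could help to separate.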